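This account rests on a few compounds, and the source may have more. Where it says the series, first, only, none or still open, it means among the compounds named here.

The measured compounds:

compound 1, `CC(C)c1ccccc1OS(=O)(=O)c1ccc(NC(=O)C(C)(C)C)cc1`, gives 6500 nM in a functional assay on MCF7 cells (Homo sapiens) for antiproliferative activity, read by sulforhodamine B assay, with a stated time of 48 h; a lower number here means a stronger inhibitor, a higher number a weaker inhibitor.
compound 2, `CC(C)(C)C(=O)Nc1ccc(S(=O)(=O)Oc2ccccc2I)cc1`, gives 6600 nM in this assay.
compound 3, `CC(C)c1ccccc1OS(=O)(=O)c1ccc(NC(=O)CCCCl)cc1`, gives 5200 nM in this assay.

Compound 1 and compound 2 differ in one place, described as iodo in place of isopropyl on an aromatic carbon. The step that this change made in this assay is a 1.0-fold higher number from compound 1 to compound 2 (0.01 log units; within the scatter). Compound 1 and compound 3 differ in another place, described as 3-chloropropyl in place of tert-butyl on a carbonyl carbon, and the step in this assay is a 1.3-fold lower number from compound 1 to compound 3 (0.10 log units; within the scatter). All three measured values thus sit close together, and none of the three compounds can be singled out as more or less active than the others on this evidence.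

Compound 4, `O=C(CCCCl)Nc1ccc(S(=O)(=O)Oc2ccccc2I)cc1`, has not yet been measured in this assay. For the measured compounds named here, it differs from compound 3 by iodo in place of isopropyl on an aromatic carbon, which is the same change as the one from compound 1 to compound 2, made on a different core; how the two cores differ is described under (3-chloropropyl in place of tert-butyl on a carbonyl carbon). Because the earlier instance of this change gave a 1.0-fold higher number from compound 1 to compound 2 (0.01 log units; within the scatter), compound 4 is expected to lie within the scatter of compound 3, the expected step being a 1.0-fold higher number from compound 3 to compound 4 (0.01 log units; within the scatter). The estimate rests on a single prior occurrence of the change, so its range is kept accordingly wide. For compound 4, the expected value in this assay is 5300 nM, with a range from 2600 nM to 10600 nM.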

Compound 4, half-maximal inhibitory concentration: 6300 nM
Compound 4: middle estimate off by 1.2-fold (0.08 log units), on the low side; measured number inside the range.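

In this assay, iodo in place of isopropyl on an aromatic carbon gives a 1.2-fold higher number from compound 3 to compound 4 (0.08 log units; within the scatter), and set beside the earlier instance of the same change, this step shows no difference between the two cores: the same change on two cores in this assay, a 1.0-fold higher number (0.01 log units; within the scatter) from compound 1 to compound 2 and a 1.2-fold higher number (0.08 log units; within the scatter) from compound 3 to compound 4, 1.2-fold (0.08 log units) apart, within the scatter of two such steps. The second change, 3-chloropropyl in place of tert-butyl on a carbonyl carbon, gives a 1.0-fold lower number from compound 2 to compound 4 (0.02 log units; within the scatter), and it too reads the same on both cores: the same change on two cores in this assay, a 1.3-fold lower number (0.10 log units; within the scatter) from compound 1 to compound 3 and a 1.0-fold lower number (0.02 log units; within the scatter) from compound 2 to compound 4, 1.2-fold (0.08 log units) apart, within the scatter of two such steps. Every one of these steps lies within the scatter, so the four compounds show that each change leaves the number in this assay unmoved on both cores, but they do not show that a change with a real step would carry over in the same way, and two cores are a narrow basis for any rule about the series.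

The compounds shown leave open whether another group on that aromatic carbon, such as a methoxy group or a nitrile, or another group on the carbonyl carbon, such as a longer chain or an amine, would give a step beyond the scatter. They also leave open whether the agreement between the cores would hold for such a step.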